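Hydroxy on the Chain of a Chloroacetyl Urea

The source may hold more compounds than are shown below. What is called first, only, known or untested is meant among the compounds shown, and "the series" means these compounds.

Measured compounds:
Compound 1, `CCCCCc1cccc(NC(=O)NCCCCl)c1`: in a functional assay on MCF7 cells (Homo sapiens) for antiproliferative activity, with a stated time of 48 h (a higher number here means a weaker inhibitor, a lower number a stronger inhibitor), compound 1 gives 26000 nM.
Compound 2, `CCCCC(O)c1cccc(NC(=O)NCCCCl)c1`: in this assay compound 2 gives > 100000 nM, a limit of the assay rather than a number.
Compound 3, `CCCCCc1cccc(NC(=O)NC(=O)CCl)c1`: in this assay compound 3 gives 8300 nM.

Among the two numbers shown, compound 3 stands lowest; its nearest neighbour is compound 1, reached by a 3.1-fold lower number from compound 1 to compound 3 (0.50 log units; beyond the scatter). Compound 4, `CCCCC(O)c1cccc(NC(=O)NC(=O)CCl)c1`, differs from compound 3 by hydroxy in place of hydrogen on a saturated chain carbon bound to an aromatic carbon and a saturated chain carbon. Among the measured compounds shown here, the one measured step that bears on this change is an at least 3.8-fold higher number from compound 1 to compound 2 (0.58 log units; beyond the scatter), the same exchange made on compound 1, which ended at the limit (the limit of > 100000 nM in this assay, at which 1 of the 3 values shown sits). From the compounds shown here alone, the direction there was clearly toward a higher number, and its full size is unknown. An upward step is therefore expected here too, a 6.0-fold higher number from compound 3 to compound 4 (0.78 log units; beyond the scatter), with a real chance that the assay again reports only a limit. Compound 4 is estimated at 50000 nM, within 15000 nM to 200000 nM.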

Compound 4, half-maximal inhibitory concentration: 5700 nM
Beside the measured number, compound 4's estimate is 8.8-fold (0.94 log units) above it, outside the stated range (below it).
By their numbers in this assay, from the lowest: compounds 4 and 3 (each within the scatter of the next); then compound 1. At a limit, above all of these: compound 2.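

Hydroxy on this saturated chain carbon does not carry the same penalty on every core: in this assay, the step with (chloromethyl)carbonyl on the amide-type nitrogen is a 1.5-fold lower number from compound 3 to compound 4 (0.16 log units; within the scatter), so the outcome of this change depends on the group at the other end of the urea: the same change on two cores in this assay, an at least 3.8-fold higher number (0.58 log units; beyond the scatter) from compound 1 to compound 2 and a 1.5-fold lower number (0.16 log units; within the scatter) from compound 3 to compound 4, at least 5.6-fold (0.74 log units) apart, beyond the scatter of two such steps. Compound 2 gives > 100000 nM, which is a limit of the assay and not a number. With hydroxy in place, exchanging 3-chloropropyl for (chloromethyl)carbonyl gives an at least 17-fold lower number from compound 2 to compound 4 (1.24 log units; beyond the scatter), and the gain from that exchange is larger on the hydroxy-bearing pair: the same change on two cores in this assay, a 3.1-fold lower number (0.50 log units; beyond the scatter) from compound 1 to compound 3 and an at least 17-fold lower number (1.24 log units; beyond the scatter) from compound 2 to compound 4, at least 5.6-fold (0.74 log units) apart, beyond the scatter of two such steps.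

Among the compounds shown here, only two cores carry this change, so it remains open how far the dependence extends. It is also unknown how an amine or a methoxy group would behave on the same carbon, or hydroxy on a longer chain.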